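High Clearance Across a Benzylamine Series: Chloro to Difluoro

The compounds below may be only part of what the source reports. "The series", "measured", "known", "first", "only" and "open" are said of these compounds alone.

Measured so far in an in vitro ADME assay on microsomes from liver (Mus musculus) for metabolic stability, read by LC-MS, tested at 0.05 uM; on this read-out lower numbers stand for slow clearance and higher numbers for fast clearance:
compound 1, `COc1cnc(-c2ccccn2)nc1N1CCCC1`, > 1000 mL/min/kg
compound 2, `COc1cnc(-c2ccccn2)nc1NCc1ccccc1Cl`, 704 mL/min/kg
compound 3, `COc1cnc(-c2ccccn2)nc1NC(C)c1ccccc1`, 570 mL/min/kg

Of the compounds shown here, three sharing one core have been tested in this assay. For compound 1 the result is a limit of the assay, > 1000 mL/min/kg, and not a number; see (the limit of > 1000 mL/min/kg in this assay, at which 1 of the 3 values shown sits). Compound 2 gives 704 mL/min/kg, and compound 3 gives 570 mL/min/kg. The two numbers for compound 2 and compound 3 lie within the scatter of each other, so neither can be said to be cleared faster or slower than the other; compound 2 simply stands at one of the two numbers shown, with compound 3 close by.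

Compound 4, `COc1cnc(-c2ccccn2)nc1NCc1ccc(F)cc1F`, has not yet been measured. It differs from compound 2 in one place: 2,4-difluorophenyl in place of 2-chlorophenyl on a saturated chain carbon bound to a nitrogen on an aromatic ring. Going by the values given here, no step between measured compounds mirrors this exchange, so there is no direct guide. Given that compound 2 and compound 3 both sit at high clearance, the step from compound 2 to compound 4 is expected to stay within the scatter, a 1.2-fold lower number from compound 2 to compound 4 (0.07 log units; within the scatter). Compound 4 is therefore estimated at 600 mL/min/kg, within a range from 250 mL/min/kg to 1400 mL/min/kg.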

Compound 4, clearance: 524 mL/min/kg
The estimate for compound 4 lay 1.1-fold (0.06 log units) above the measured number; the range from low to high includes it.
By their numbers in this assay, from the lowest: compounds 4, 3 and 2 (each within the scatter of the next). At a limit, above all of these: compound 1.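

Going by these compounds alone, the exchange of 2-chlorophenyl for 2,4-difluorophenyl on a saturated chain carbon bound to a nitrogen on an aromatic ring gives the first step that can be read in this assay, and it is a 1.3-fold lower number from compound 2 to compound 4 (0.13 log units; within the scatter). Within the data shown here, the earlier compounds offered no pair that differed in one place, so this is the first direct view of this position, and it shows that trading one chlorine for two fluorines on the phenyl ring leaves the two numbers indistinguishable, with both compounds still cleared fast on this read-out. Nothing measured in this series bears on why these two compounds cannot be told apart.

From the compounds shown here alone, whether another group on the phenyl ring, such as a nitrile, a methoxy, a trifluoromethyl or a carboxylic acid, would give a number beyond the scatter from compound 2 remains open. Equally open, going by these compounds, is what a longer chain between the phenyl ring and the nitrogen, or an amine on that ring, would do to clearance.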